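Glycyl Cap on the Ring Nitrogen of a Thiol Inhibitor

This account rests on a few compounds, and the source may have more. Where it says the series, first, only, none or still open, it means among the compounds named here.

Measured so far:
- compound 1, `O=C(O)C(CS)C1CCNCC1`: 195 nM
- compound 2, `O=C(O)C(CS)C1CCCNC1`: 19000 nM; > 30000 nM (2 entries)

Going by the values given here, in an assay on isolated protein for inhibition of carboxypeptidase B (Sus scrofa) (a lower number here means a stronger inhibitor, a higher number a weaker inhibitor), compound 1 gives 195 nM and is the only compound here with a single clear number. Compound 2 gives 19000 nM; > 30000 nM (2 entries) in this assay. For compound 2 the entries with a greater-than sign are limits of the assay, not numbers. Taken together, the values of compound 1 and compound 2 lie far apart, so the pair says little about small changes at the ring nitrogen.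

Compound 3, `NCC(=O)N1CCC(C(CS)C(=O)O)CC1`, has not yet been measured in this assay. It differs from compound 1 in one place: (aminomethyl)carbonyl in place of hydrogen on an amine nitrogen in a ring. No measured step of this kind exists among the compounds shown, so the expectation rests on the change alone. Capping the ring nitrogen with a group that carries its own amine is expected to weaken inhibition in this assay by a step beyond the usual scatter, as a 7.7-fold higher number from compound 1 to compound 3 (0.89 log units; beyond the scatter). Compound 3 is therefore estimated at 1500 nM, with a range from 300 nM to 8000 nM.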

Compound 3, half-maximal inhibitory concentration: > 30000 nM
Compound 3: no number, only a limit; the forecaster's own chance of this, stated with the estimate: 5%; middle value at least 20-fold (1.30 log units) away from the limit.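

In this assay compound 3 gives > 30000 nM, which is a limit of the assay and not a number. Even so, the direction and the rough size of the change are clear: placing (aminomethyl)carbonyl on the amine nitrogen in the ring, where compound 1 carries only hydrogen, gives an at least 150-fold higher number from compound 1 to compound 3 (2.18 log units; beyond the scatter), so this position does not accept this cap, even though the cap brings an amine of its own. The printed step is only a lower bound, and the full size of the loss cannot be read, because the measurement stops at the limit of the assay: the limit of > 30000 nM in this assay, at which 1 of the 3 values shown sits.

The compounds shown leave open which part of the cap is responsible, the carbonyl attached to the ring nitrogen or the amine at its far end; an acetyl group, which keeps the carbonyl and lacks the amine, would begin to separate the two. They also leave open whether this nitrogen accepts any substituent at all, a question that a single methyl group, which adds no carbonyl, or a longer chain ending in an amine could help to answer.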